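Swapping the ether-linked ring of an inhibitor

A few compounds are considered here, and "the series" means these few. Any claim that something is new, unique, unknown or untested is made for them only; others in the source may bear on it.

Measured compounds in a functional assay on Jurkat cells (Homo sapiens) for inhibition; a higher number here means a weaker inhibitor, a lower number a stronger inhibitor:
Compound 1, `COC(=O)c1cc(OCC(=O)[C@H](CC(=O)O)NC(=O)[C@@H](NC(=O)COc2cccc3ccccc23)C(C)C)no1`, gives 71000 nM.
Compound 2, `CC(C)[C@H](NC(=O)COc1cccc2ccccc12)C(=O)N[C@@H](CC(=O)O)C(=O)CSc1nnc(-c2ccccc2)o1`, gives 150000 nM.
Compound 3, `CC(C)[C@H](NC(=O)COc1cccc2ccccc12)C(=O)N[C@@H](CC(=O)O)C(=O)CSc1nc[nH]n1`, reaches only the limit of the assay, > 200000 nM.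

Among these, compound 1 carries the lowest number, and the nearest measured neighbour is compound 2, separated by a 2.1-fold higher number from compound 1 to compound 2 (0.32 log units; beyond the scatter). The move to compound 3 reads an at least 2.8-fold higher number from compound 1 to compound 3 (0.44 log units; beyond the scatter), and between compound 2 and compound 3 the step is an at least 1.3-fold higher number from compound 2 to compound 3 (0.12 log units; that floor lies within the scatter), with the limit of > 200000 nM in this assay, at which 1 of the 3 values shown sits, behind the last of those.

Compound 4, `CC(C)[C@H](NC(=O)COc1cccc2ccccc12)C(=O)N[C@@H](CC(=O)O)C(=O)COc1ccnc(C(F)(F)F)n1`, departs from compound 1 as follows: 2-(trifluoromethyl)pyrimidin-4-yl in place of 5-(methoxycarbonyl)-1,2-oxazol-3-yl on an oxygen on a saturated carbon. This differs from the two measured steps, which exchanged the whole (5-(methoxycarbonyl)-1,2-oxazol-3-yl)oxy group for a ring on a sulfur, each time a modest weakening. Here the oxygen on the saturated carbon is kept and only the ring changes. Those steps therefore bear only loosely on this one; the expectation is a step within the scatter or a modest weakening, not a gain.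

The estimated result for compound 4 is 90000 nM, ranging from 35000 nM to 200000 nM, which would mean a 1.3-fold higher number from compound 1 to compound 4 (0.10 log units; within the scatter).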

Compound 4, half-maximal inhibitory concentration: 37000 nM
For compound 4 the middle estimate is 2.4-fold (0.39 log units) above the measured one; measured number inside the range.
By their numbers in this assay, from the lowest: compounds 4 and 1 (each within the scatter of the next); then compound 2. At a limit, above all of these: compound 3.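

With the oxygen on the saturated carbon kept, 2-(trifluoromethyl)pyrimidin-4-yl can stand in place of 5-(methoxycarbonyl)-1,2-oxazol-3-yl with no readable loss in this assay, which reads a 1.9-fold lower number from compound 1 to compound 4 (0.28 log units; within the scatter), so a second and quite different ring on this oxygen performs on a par with the first. The sulfur-linked rings now sit apart from this oxygen-linked ring as well, with a 4.1-fold lower number from compound 2 to compound 4 (0.61 log units; beyond the scatter) and an at least 5.4-fold lower number from compound 3 to compound 4 (0.73 log units; beyond the scatter), so both oxygen-linked compounds, 1 and 4 in the series, lie clear of both sulfur-linked ones, though all of these numbers remain high. Compound 3 stays a limit of the assay and not a number: the limit of > 200000 nM in this assay, at which 1 of the 4 values shown sits.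

Going by these compounds, each step from sulfur to oxygen changes the ring and the linking atom together, so the part played by each alone stays open, as does whether a methyl or a nitrile in place of the trifluoromethyl on the pyrimidine would read the same. The compounds shown offer no measured reason for any of these steps.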